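Changing the Aryl Group on the Ring Nitrogen

The source may hold more compounds than are shown below. What is called first, only, known or untested is meant among the compounds shown, and "the series" means these compounds.

For the measured compounds named here, compound 3 `COc1cc2c(Oc3ccc(NC(=O)c4cn(-c5ccccc5OC(F)(F)F)cn4)cc3F)ccnc2cc1OCCCN1CCCCC1` gives 270 nM in a functional assay on A549 cells (Homo sapiens) for cytotoxicity, read by MTT assay, with a stated time of 72 h (on this read-out lower numbers stand for stronger inhibition and higher numbers for weaker inhibition), the second highest of the three numbers measured so far. Compound 1 `COc1cc2c(Oc3ccc(NC(=O)c4cn(-c5ccccc5OC)cn4)cc3F)ccnc2cc1OCCCN1CCN(C)CC1` gives 70 nM in this assay, and compound 2 `COc1cc2c(Oc3ccc(NC(=O)c4cn(-c5ccc(Cl)cc5)cn4)cc3F)ccnc2cc1OCCCN1CCN(C)CC1` gives 5200 nM. Compound 4 `COc1cc2c(Oc3ccc(NC(=O)c4cn(-c5ccc(Cl)cc5Cl)cn4)cc3F)ccnc2cc1OCCCN1CCCCC1` differs from compound 3 in one place: 2,4-dichlorophenyl in place of 2-(trifluoromethoxy)phenyl on an aromatic nitrogen. Going by the values given here, the only measured step that bears on this change is a 74-fold higher number from compound 1 to compound 2 (1.87 log units; beyond the scatter), where the group on the same ring nitrogen was exchanged in a related way. That step was large, so a clearly higher number is expected for compound 4 in this assay, although the two exchanges are not identical and the size is therefore uncertain. The expected step is a 7.4-fold higher number from compound 3 to compound 4 (0.87 log units; beyond the scatter). Compound 4 is accordingly estimated at 2000 nM, within a range from 500 nM to 8000 nM.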

Compound 4, half-maximal inhibitory concentration: 7490 nM
Compound 4: middle estimate off by 3.7-fold (0.57 log units), on the low side; low and high end bracket the measured number.
By their numbers in this assay, from the lowest: compound 1; then compound 3; then compounds 2 and 4 (each within the scatter of the next).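

In this assay, the exchange on the ring nitrogen gives a 28-fold higher number from compound 3 to compound 4 (1.44 log units; beyond the scatter), so a large rise now appears with a second pair of compounds that carry a different side chain. In both measured steps on this nitrogen, a chlorine-bearing phenyl replaces an oxygen-bearing phenyl and the number rises, and no compound shown goes against this. No measurement here explains the rise. The chlorine atoms and the loss of the oxygen-bearing group cannot be separated, and a plain phenyl or a 2-chlorophenyl on this nitrogen would help to tell them apart.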